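The source may report more compounds than this note shows. Statements on the series, on what has been measured and on what is new or still open speak of the compounds shown alone.

In a physicochemical assay for lipophilicity, read by HPLC, at pH 7.4 (on this read-out lower numbers stand for lower lipophilicity and higher numbers for higher lipophilicity), compound 1 (`CCC/N=C1\S/C(=C\c2ccc(O)c(Cl)c2)C(=O)N1c1ccccc1O`) reads 2.7 and compound 2 (`CCC/N=C1\S/C(=C\c2ccc(O)c(C)c2)C(=O)N1c1ccccc1C`) reads 3.8 on the scale. Compound 3 (`COCC/N=C1\S/C(=C\c2ccc(O)c(Cl)c2)C(=O)N1c1ccccc1C`) reads 2.9 here, within the scatter of compound 1 and well short of compound 2, a gap beyond the scatter. The change from compound 3 to compound 4 (`CCC/N=C1\S/C(=C\c2ccc(O)c(Cl)c2)C(=O)N1c1ccccc1C`) is methyl in place of methoxy on a saturated chain carbon, two bonds along the chain from a double-bonded nitrogen. Going by the values given here, no measured pair isolates this change. Compound 2, also with propyl, reads 3.8 but differs elsewhere, while compound 1, also with propyl, reads 2.7 and argues against a simple reading. The expected step is a rise beyond the scatter, a number 0.70 log units higher from compound 3 to compound 4 (beyond the scatter) in size. For compound 4 the estimated value is 3.6 (expected range 3.2 to 4).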

Compound 4, distribution coefficient: 3.8
Estimate against measurement, compound 4: 0.20 log units below, within the range that was stated.
By their numbers in this assay, from the lowest: compounds 1 and 3 (each within the scatter of the next); then compounds 2 and 4 (each within the scatter of the next).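

In this assay, going by these compounds alone, the change at this position now stands isolated: methyl in place of methoxy gives a number 0.90 log units higher from compound 3 to compound 4 (beyond the scatter), so compound 2 was not the only propyl compound reading high. Chloro in place of methyl on an aromatic carbon gives no change at the digits printed from compound 2 to compound 4 (within the scatter), while methyl in place of hydroxy on an aromatic carbon gives a number 1.10 log units higher from compound 1 to compound 4 (beyond the scatter), which ties the low reading of compound 1 to that hydroxy despite its propyl chain. Nothing at hand gives a reason for these steps. On these data alone, whether the methoxy step holds with the hydroxy of compound 1 remains open. So does the reading of an amine or a longer chain at this position.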